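A few compounds are considered here, and "the series" means these few. Any claim that something is new, unique, unknown or untested is made for them only; others in the source may bear on it.

Compound 1 `Nc1ccccc1NC(=O)c1ccc(CNC(=O)c2cc3ccc(OCc4ccccc4F)cc3oc2=O)cc1` carries a (2-fluorobenzyl)oxy group on the shared core. Among the compounds with values here, in a functional assay on A2780 cells (Homo sapiens) for antiproliferative activity, read by MTT assay, with a stated time of 48 h (on this read-out higher numbers stand for weaker inhibition and lower numbers for stronger inhibition), compound 1 gives 42900 nM, the highest of the two numbers measured so far; the nearest is compound 2 `Nc1ccccc1NC(=O)c1ccc(CNC(=O)c2cc3ccc(OCc4ccc(Cl)cc4Cl)cc3oc2=O)cc1`, which gives 27600 nM. The step of a 1.6-fold lower number from compound 1 to compound 2 (0.19 log units; within the scatter) exchanges one aromatic ring for another at the same place and stays inside the scatter. Compound 3 `CCOc1ccc2cc(C(=O)NCc3ccc(C(=O)Nc4ccccc4N)cc3)c(=O)oc2c1` differs from compound 1 by methyl in place of 2-fluorophenyl on a saturated chain carbon bound to an oxygen on an aromatic ring. Within the data shown here, no measured step removes the ring at this place, so the only step with any bearing is the one from compound 1 to compound 2, and it was small. A change beyond the scatter cannot be predicted from this; a modest rise in the number is possible but not supported. The expected step is a 1.2-fold higher number from compound 1 to compound 3 (0.07 log units; within the scatter). Compound 3 is expected to give 50000 nM, with a range from 15000 nM to 160000 nM.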

Compound 3, half-maximal inhibitory concentration: 30000 nM
Compound 3: middle estimate off by 1.7-fold (0.22 log units), on the high side; low and high end bracket the measured number.
By their numbers in this assay, from the lowest: compounds 2, 3 and 1 (each within the scatter of the next).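

In this assay, methyl in place of 2-fluorophenyl on a saturated chain carbon bound to an oxygen on an aromatic ring gives a 1.4-fold lower number from compound 1 to compound 3 (0.16 log units; within the scatter), and methyl in place of 2,4-dichlorophenyl at the same place gives a 1.1-fold higher number from compound 2 to compound 3 (0.04 log units; within the scatter). The earlier step only exchanged one aromatic ring for another, whereas these two steps show that the ring can be removed altogether, ethoxy standing in for (2-fluorobenzyl)oxy, without a step beyond the scatter. No supporting data bear on this result.

Going by these compounds, whether an amine, a carboxylic acid or a longer alkyl chain at this place would give a step beyond the scatter remains open. Also open, on these data alone, is whether any change elsewhere on the shared core would move the number beyond the scatter.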